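Compound 2 to compound 3: azetidin-1-yl to cyclopropylamino

This account rests on a few compounds, and the source may have more. Where it says the series, first, only, none or still open, it means among the compounds named here.

In a functional assay on MGC-803 cells (Homo sapiens) for inhibition, read by sulforhodamine B assay (on this read-out lower numbers stand for stronger inhibition and higher numbers for weaker inhibition), compound 2 (`O=C1C(N2CCC2)=CC(=O)c2c1nc1n2[C@H]2OC[C@@H](O)[C@H]2OC1`) gives > 16000 nM as a limit of the assay and not a number. Compound 2 thus stands at the limit of > 16000 nM in this assay, at which 1 of the 2 values shown sits, and has no exact position. For the measured compounds named here, compound 1 (`O=C1C(Nc2ccc(I)cc2)=CC(=O)c2c1nc1n2[C@H]2OC[C@@H](O)[C@H]2OC1`) gives 2150 nM in this assay as the only exact reading so far.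

Compound 3 (`O=C1C(NC2CC2)=CC(=O)c2c1nc1n2[C@H]2OC[C@@H](O)[C@H]2OC1`) carries cyclopropylamino in place of azetidin-1-yl on a double-bonded ring carbon and so gains a hydrogen-bond donor. Going by the values given here, the single measured step is an at least 7.4-fold higher number from compound 1 to compound 2 (0.87 log units; beyond the scatter) and lies beyond the scatter, though its size is only a bound. It bears only in part: compound 3 shares the amino link of compound 1 but lacks its 4-iodophenyl group.

A modest move toward lower numbers is expected, estimated as an at least 2.2-fold lower number from compound 2 to compound 3 (0.35 log units; beyond the scatter) in this assay with a real chance of another limit. The expected value for compound 3 is 7000 nM with an estimated range of 2500 nM to 20000 nM in this assay.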

Compound 3, half-maximal inhibitory concentration: > 4000 nM
Compound 3: a limit, no number (the forecaster's own chance of this, stated with the estimate: 35%); the middle value is on the limit's open side.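

In this assay, compound 3 gives a limit and not a number: the limit of > 4000 nM in this assay, at which 1 of the 3 values shown sits.

Cyclopropyl in place of 4-iodophenyl on the amine nitrogen gives an at least 1.8-fold higher number from compound 1 to compound 3 (0.26 log units; that floor lies within the scatter), so this change alone does not establish a loss against compound 1. The step between compound 2 and compound 3 cannot be read: both ends are limits, and the data do not tell whether the hydrogen-bond donor of cyclopropylamino changes the reading relative to azetidin-1-yl.

For the compounds shown here, compound 1 remains the only exact reading, so it is open whether that reading depends on the iodine, the aromatic ring or the size of the group on the amine nitrogen. Phenylamino and cyclohexylamino at this position would separate these features, provided their readings fall inside the range of the assay.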